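The source may hold more compounds than are shown below. What is called first, only, known or untested is meant among the compounds shown, and "the series" means these compounds.

Measured so far:
- compound 1 `Cc1cccc(NC(=O)[C@@H]2CCCN2S(=O)(=O)c2cccc3cccnc23)c1`: 25500 nM
- compound 2 `O=C(Nc1ccccc1)[C@@H]1CCCN1S(=O)(=O)c1cccc2cccnc12`: 35600 nM
- compound 3 `CCc1ccccc1NC(=O)[C@@H]1CCCN1S(=O)(=O)c1cccc2cccnc12`: > 50000 nM

In an ADME assay on HEp-2 cells (Homo sapiens) for cytotoxicity (on this read-out lower numbers stand for higher toxicity in this test and higher numbers for lower toxicity in this test), compound 2 gives 35600 nM. This is the higher of the two numbers recorded; the nearest is compound 1, and the difference a 1.4-fold higher number from compound 1 to compound 2 (0.14 log units; within the scatter) is small. For compound 3 the result > 50000 nM is a limit of the assay and not a number, so that the limit of > 50000 nM in this assay, at which 1 of the 3 values shown sits, marks where the measurement stopped.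

Compound 4 `Cc1ccc(Cl)c(NC(=O)[C@@H]2CCCN2S(=O)(=O)c2cccc3cccnc23)c1` has not yet been measured. Compared with compound 2 the change is 2-chloro-5-methylphenyl in place of phenyl on an amide-type nitrogen, so a larger ring with a chlorine and a methyl takes the place of the bare phenyl on the amide nitrogen.

For the measured compounds named here, two measured steps bear on this. The step of a 1.4-fold higher number from compound 1 to compound 2 (0.14 log units; within the scatter) removed a methyl from the same ring and moved the number only within the scatter. The step of an at least 1.4-fold higher number from compound 2 to compound 3 (0.14 log units; that floor lies within the scatter) added an ethyl to that ring and reached the limit, with a floor still within the scatter. Neither change to the ring shifted the read-out in this assay by more than the scatter, so a step of similar size, if any, is expected for compound 4.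

The expected step is a 1.2-fold higher number from compound 2 to compound 4 (0.07 log units; within the scatter). For compound 4 the estimate in this assay is 42000 nM, within the range 18000 nM to 100000 nM.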

Compound 4, half-maximal cytotoxic concentration: > 50000 nM
Compound 4 gave a limit, no number; the forecaster's own chance of this, stated with the estimate: 40%; middle value at least 1.1-fold (0.07 log units) away from the limit.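

Compound 4 brings the first chlorine on the ring in this set, and in this assay the added chlorine alone gives an at least 1.9-fold higher number from compound 1 to compound 4 (0.29 log units; that floor lies within the scatter), while the full exchange of the bare phenyl for 2-chloro-5-methylphenyl gives an at least 1.4-fold higher number from compound 2 to compound 4 (0.14 log units; that floor lies within the scatter). Both floors lie within the scatter, so neither step is shown to be a real change, although the true size of each could be larger than its floor, and nothing here points to higher toxicity in this test with the chlorine in place. With compound 4 a second ring pattern ends at a limit rather than a number, the step from compound 3 to compound 4 cannot be read, and further changes to this ring that end there could not be ranked against each other: the limit of > 50000 nM in this assay, at which 2 of the 4 values shown sit.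

Going by these compounds, whether an amine or a carboxylic acid on this ring would give a lower number remains open, as does the effect of a longer chain such as butyl in place of the ethyl of compound 3. On these data alone, it is also open how a chlorine would read on the bare phenyl of compound 2 without the methyl, and how far compound 3 and compound 4 really lie from each other.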